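Pyrazoline Series: Swapping the Ring-Nitrogen Substituent for a Sulfonyl

The source may report more compounds than this note shows. Statements on the series, on what has been measured and on what is new or still open speak of the compounds shown alone.

Measured compounds and their values:
- compound 1, `CN(C)c1ccc(C2CC(c3ccc(-n4cncn4)cc3)=NN2)cc1`: 7%
- compound 2, `CN(C)c1ccc(C2CC(c3ccc(-n4cncn4)cc3)=NN2C(=O)CCCl)cc1`: 3.7%
- compound 3, `CN(C)c1ccc(C2CC(c3ccc(-n4cncn4)cc3)=NN2C(=O)/C=C/c2ccccc2)cc1`: 8.5%

In a functional assay on MDA-MB-231 cells (Homo sapiens) for inhibition, read by sulforhodamine B assay, tested at 10 uM (on this read-out higher numbers stand for more inhibition at the one concentration tested (going by the name of the read-out) and lower numbers for less inhibition), compound 3 shows the highest of the three numbers, but the two steps that lead to it, a number 1.5 percentage points higher from compound 1 to compound 3 (within the scatter) and a number 4.8 percentage points higher from compound 2 to compound 3 (within the scatter), are both within the scatter, so the three compounds are not separable on this assay.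

Compound 4, `CN(C)c1ccc(C2CC(c3ccc(-n4cncn4)cc3)=NN2S(=O)(=O)c2ccc(Br)cc2)cc1`, has not been measured. It differs from compound 3 in one place: (4-bromophenyl)sulfonyl in place of (2-phenylethenyl)carbonyl on an amine nitrogen in a ring.

For the measured compounds named here, the steps that bear on this change are those that alter the same ring nitrogen: a number 3.3 percentage points lower from compound 1 to compound 2 (within the scatter) and a number 1.5 percentage points higher from compound 1 to compound 3 (within the scatter), and the swap of the group on the carbonyl, a number 4.8 percentage points higher from compound 2 to compound 3 (within the scatter). All three stay within the scatter. On that basis the expected step from compound 3 to compound 4 is none beyond the scatter, a number 1.5 percentage points lower from compound 3 to compound 4 (within the scatter). Compound 4 is therefore estimated to give 7%, with a range from 0% to 20%.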

Compound 4, a percentage reported as inhibition, at one concentration (the size of the read-out at that concentration, not a potency): 10.4%
Compound 4: the middle estimate sits 3.4 percentage points below what was measured; the measured number falls inside the stated range.
By their numbers in this assay, from the lowest: compounds 2, 1, 3 and 4 (each within the scatter of the next).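

In this assay the step from the carbonyl series to a sulfonyl link is a number 1.9 percentage points higher from compound 3 to compound 4 (within the scatter), while the other two steps are a number 6.7 percentage points higher from compound 2 to compound 4 (within the scatter) and a number 3.4 percentage points higher from compound 1 to compound 4 (within the scatter). So a (4-bromophenyl)sulfonyl group on this ring nitrogen, the first group here attached through sulfur and not through a carbonyl, cannot be told apart from hydrogen or from either carbonyl group, and no change at this position has yet moved the number beyond the scatter. Nothing measured here offers an explanation for this flat picture. As far as these compounds go, it remains open whether a quite different group on this nitrogen, such as an amine on a longer chain or a carboxylic acid, would separate from these four compounds. From the compounds shown here alone, whether the bromine itself matters also remains open.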